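The source may hold more compounds than are shown below. What is called first, only, known or untested is meant among the compounds shown, and "the series" means these compounds.

Compound 1 `O=[N+]([O-])c1ccc2c(c1)N(S(=O)(=O)c1ccc(-c3cnc(C4CC4)o3)cc1)CCCO2`: 119 nM
Compound 2 `O=S(=O)(c1ccc(-c2cnc(C3CC3)o2)cc1)N1CCOCc2ccccc21`: 137 nM

Of the compounds shown here, two have so far been tested in a functional assay on PC-3 cells (Homo sapiens) for antiproliferative activity, read by MTT assay, with a stated time of 72 h; on this read-out lower numbers stand for stronger inhibition and higher numbers for weaker inhibition. Compound 1 gives 119 nM in this assay, and compound 2 gives 137 nM. The two numbers sit within the usual scatter of repeated measurements of each other, so neither compound can be called stronger or weaker on this evidence; compound 1 and compound 2 simply stand together at the same level.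

The new compound 3 `Cc1ccc2c(c1)N(S(=O)(=O)c1ccc(-c3cnc(C4CC4)o3)cc1)CCCO2` keeps the shared core of compound 1 and changes one group on the fused ring: methyl in place of nitro on an aromatic carbon. Among the measured compounds shown here, no pair of measured compounds differs in a way that tracks this particular swap, so there is no measured step to lean on. With both measured compounds at a similar level, the plain expectation is that compound 3 stays near them, and the step of a 1.6-fold higher number from compound 1 to compound 3 (0.20 log units; within the scatter) is expected to be small and within the scatter, with no clear direction. Compound 3 is estimated at 190 nM, within a range from 60 nM to 650 nM.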

Compound 3, half-maximal inhibitory concentration: 41 nM
Estimate against measurement, compound 3: 4.6-fold (0.67 log units) above; the measured number lies below the stated range.
By their numbers in this assay, from the lowest: compound 3; then compounds 1 and 2 (each within the scatter of the next).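

In this assay, among the compounds shown here, methyl in place of nitro on an aromatic carbon gives a 2.9-fold lower number from compound 1 to compound 3 (0.46 log units; beyond the scatter) and this is the first step that can be read beyond the scatter. It shows that this place on the fused ring is not indifferent to the group it carries, and that nitro is not needed for a number at this level on the shared core: the leaving group has three heavy atoms and two hydrogen-bond acceptors, while the entering methyl has one carbon and no acceptors. This single pair cannot separate those differences, and no other measurement here bears on why the number falls.

From the compounds shown here alone, whether an amine, a methoxy group or a chlorine atom on the same carbon would stand closer to methyl or to nitro stays open, as does whether a longer chain such as ethyl would keep the lower number. Going by these compounds, the step also rests on one pair in one kind of cell, so whether it holds on other cells or on other cores remains unknown.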